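The source may hold more compounds than are shown below. What is called first, only, known or untested is meant among the compounds shown, and "the series" means these compounds.

Going by the values given here, compound 3 `COc1ccc(-c2cc(-c3ccccc3-c3ccccc3)n[nH]2)cc1` gives the lowest number of the three measured so far in a functional assay on SW-620 cells (Homo sapiens) for inhibition, read by MTT assay, with a stated time of 48 h (on this read-out lower numbers stand for stronger inhibition of growth and higher numbers for weaker inhibition of growth), at 890 nM. Compound 1 `COc1ccc(-c2cc(-c3ccc([N+](=O)[O-])cc3)[nH]n2)cc1` gives 14300 nM and compound 2 `COc1ccc(-c2cc(-c3ccccc3)n[nH]2)cc1` gives 27200 nM. Among the compounds with values here, the single step between measured compounds that differ in one place, a 31-fold lower number from compound 2 to compound 3 (1.49 log units; beyond the scatter), concerns phenyl in place of hydrogen and does not touch the change now in view. Compound 4 `Oc1ccccc1-c1cc(-c2ccccc2-c2ccccc2)n[nH]1` differs from compound 3 by 2-hydroxyphenyl in place of 4-methoxyphenyl on an aromatic carbon. Within the data shown here, no measured step bears on this exchange, so its size and direction in this assay cannot be read from the series, and a step within the usual scatter is assumed as the working case. Compound 4 is accordingly expected at 1200 nM, with a range of 300 nM to 5000 nM. The expected step is a 1.3-fold higher number from compound 3 to compound 4 (0.13 log units; within the scatter).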

Compound 4, concentration for 50% growth inhibition: 10600 nM
For compound 4 the middle estimate is 8.8-fold (0.95 log units) below the measured one; measured number outside the range, above it.
By their numbers in this assay, from the lowest: compound 3; then compounds 4, 1 and 2 (each within the scatter of the next, the first and the last beyond it).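

In this assay this position proves sensitive to the aryl group it carries: 2-hydroxyphenyl in place of 4-methoxyphenyl gives a 12-fold higher number from compound 3 to compound 4 (1.08 log units; beyond the scatter). The low number of compound 3 therefore does not rest on the added phenyl alone, but also on the group at this position. Nothing at hand accounts for this step.

The exchange changes both the oxygen substituent and its place on the ring, and the compounds shown cannot separate the two. On these data alone, how an amine or a carboxylic acid in place of the hydroxyl would read remains open.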